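Swapping Methoxy for Chloro on the Aromatic Ring

This account rests on a few compounds, and the source may have more. Where it says the series, first, only, none or still open, it means among the compounds named here.

Compound 1 `COc1ccc(/C(C)=C(/C)C(=O)NC2CC2)cc1` gives 300 mg/kg in a toxicity assay on the whole organism (strain Icem-CET (SPF Caw)) for cytotoxicity, with Mus musculus as the target; a higher number here means that more compound is needed for the effect, a lower number that less compound is needed. Among the compounds with values here, its only neighbour is compound 2 `C=CCNC(=O)/C(C)=C(/C)c1ccc(OC)cc1`, which gives 400 mg/kg in this assay; the step of a 1.3-fold higher number from compound 1 to compound 2 (0.12 log units; within the scatter) comes from allyl in place of cyclopropyl on an amide-type nitrogen. Compound 3 `C/C(C(=O)NC1CC1)=C(\C)c1ccc(Cl)cc1` differs from compound 1 elsewhere: chloro in place of methoxy on an aromatic carbon. Within the data shown here, no measured step touches this aromatic carbon, so the one step at hand, on the amide-type nitrogen, offers no guide to the change. The step of no change at the digits printed from compound 1 to compound 3 (within the scatter) is therefore expected to lie within the scatter. The estimate for compound 3 is 300 mg/kg, spanning 150 mg/kg to 600 mg/kg.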

Compound 3, dose for half-maximal effect: 600 mg/kg
Beside the measured number, compound 3's estimate is 2.0-fold (0.30 log units) below it, and the stated range covers the measured number.
By their numbers in this assay, from the lowest: compounds 1, 2 and 3 (each within the scatter of the next).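

In this assay, within the data shown here, the first measured step at this aromatic carbon is a 2.0-fold higher number from compound 1 to compound 3 (0.30 log units; within the scatter) and so shows that this position can take a single chlorine atom in place of methoxy without leaving the usual scatter. The number stays within that scatter even though the swap removes a hydrogen-bond acceptor from the ring. Nothing measured here explains this result. The compounds shown leave open how an amine or a carboxylic acid on this aromatic carbon would read. They also leave open whether chloro gives a similar step when allyl sits on the amide-type nitrogen.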